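From methoxycarbonyl to diethylcarbamoyl: compound 1 and compound 4

The source may report more compounds than this note shows. Statements on the series, on what has been measured and on what is new or still open speak of the compounds shown alone.

In an in vitro ADME assay on microsomes from liver (Homo sapiens) for metabolic stability (on this read-out higher numbers stand for fast clearance and lower numbers for slow clearance), compound 1 `COC(=O)[C@H]1CC[C@@H](n2/c(=N/C(=O)c3ccccc3)[nH]c3ccc(CN4CCCCC4)cc32)CC1` gives 85 mL.min-1.g-1, within the scatter of compound 2 `CC(C)NC(=O)[C@H]1CC[C@@H](n2/c(=N/C(=O)c3cc(F)cc(Cl)c3)[nH]c3ccc(CN4CCC(C(C)(C)O)CC4)cc32)CC1` at 83 mL.min-1.g-1 and compound 3 `CC(C)NC(=O)[C@H]1CC[C@@H](n2/c(=N/C(=O)c3ccc(F)c(Cl)c3)[nH]c3ccc(CN4CCC(C(C)(C)O)CC4)cc32)CC1` at 83 mL.min-1.g-1. Compound 4 `CCN(CC)C(=O)[C@H]1CC[C@@H](n2/c(=N/C(=O)c3ccccc3)[nH]c3ccc(CN4CCCCC4)cc32)CC1` carries diethylamino in place of methoxy on a carbonyl carbon. Among the compounds with values here, the only measured step shows no change at the digits printed from compound 2 to compound 3 (within the scatter). Within the data shown here, that step swaps a different group, so it offers only indirect guidance, and no measured step covers this change. Starting from compound 1 at 85 mL.min-1.g-1, no shift beyond the scatter is expected in this assay, and the direction remains open. The expected step is a 1.1-fold lower number from compound 1 to compound 4 (0.05 log units; within the scatter). For compound 4 the estimated value is 75 mL.min-1.g-1, with an expected range of 35 mL.min-1.g-1 to 130 mL.min-1.g-1.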

Compound 4, intrinsic clearance in microsomes: 364 mL.min-1.g-1
Beside the measured number, compound 4's estimate is 4.9-fold (0.69 log units) below it; the measured number lies above the stated range.
By their numbers in this assay, from the lowest: compounds 2, 3 and 1 (each within the scatter of the next); then compound 4.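

Diethylamino in place of methoxy on a carbonyl carbon gives a 4.3-fold higher number from compound 1 to compound 4 (0.63 log units; beyond the scatter) in this assay, the only step so far that lies beyond the scatter. The group on this carbonyl carbon can therefore shift clearance in microsomes with the rest of compound 1 unchanged. No evidence at hand accounts for this step.

A single pair cannot separate the loss of methoxy from the entry of diethylamino. On these data alone, how a carboxylic acid or a dimethylamino group would read at this carbonyl carbon remains open.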